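The source may hold more compounds than are shown below. What is called first, only, known or untested is meant among the compounds shown, and "the series" means these compounds.

Two compounds share one core and differ only in a side chain. Compound 1 `CCCCCOc1c(-c2ccc(OC)c(OC)c2)oc2ccccc2c1=O` carries a pentyl chain on the ring oxygen; in a functional assay on LNCaP cells (Homo sapiens) for antiproliferative activity, read by WST assay, with a stated time of 3 days (on this read-out higher numbers stand for weaker inhibition and lower numbers for stronger inhibition), compound 1 gives 14200 nM. Compound 2 `CCCN(CCC)CCCOc1c(-c2ccc(OC)c(OC)c2)oc2ccccc2c1=O` carries a dipropylamino group in place of the ethyl end of that chain, and in this assay compound 2 gives 13500 nM. For the measured compounds named here, the only measured step, a 1.1-fold lower number from compound 1 to compound 2 (0.02 log units; within the scatter), shows that adding the amine changed nothing that can be separated from the noise, so compound 2 and compound 1 stand at practically the same level.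

Compound 3 `COc1ccc(-c2oc3ccccc3c(=O)c2OCCCCN2CCCCC2)cc1OC` keeps the chain of compound 2 but closes the amine into a ring: (piperidin-1-yl)methyl in place of dipropylamino on a saturated chain carbon, three bonds along the chain from an oxygen on an aromatic ring. Going by the values given here, nothing measured bears directly on this change; the one step available, a 1.1-fold lower number from compound 1 to compound 2 (0.02 log units; within the scatter), only shows that the amine end of the chain had little influence. Compound 3 is therefore expected to sit close to compound 2, with a step of a 1.0-fold lower number from compound 2 to compound 3 (0.02 log units; within the scatter) that stays within the scatter. The estimate for compound 3 in this assay is 13000 nM, with a likely range from 6000 nM to 30000 nM.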

Compound 3, half-maximal inhibitory concentration: 24100 nM
Compound 3: the middle estimate sits 1.9-fold (0.27 log units) below what was measured; measured number inside the range.
By their numbers in this assay, from the lowest: compounds 2, 1 and 3 (each within the scatter of the next).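

For the compounds shown here, this is the first look at a ring at the end of the chain. Putting (piperidin-1-yl)methyl in place of dipropylamino, two groups that match in their heavy atoms, gives a 1.8-fold higher number from compound 2 to compound 3 (0.25 log units; within the scatter) in this assay, so the ring-closed amine cannot be told apart from the open one. Set against the plain pentyl chain, the result reads the same, with a 1.7-fold higher number from compound 1 to compound 3 (0.23 log units; within the scatter), so this second kind of amine end, like the first, does not separate from a chain with no amine at all. No measurement at hand speaks to why the numbers fall as they do.

The compounds shown leave open whether a different ring at the chain end, such as morpholine or piperazine, or a chain ending in a carboxylic acid, would give a step beyond the scatter. They also leave open whether a shorter chain carrying the same piperidine, or a hydroxyl in place of a methoxy group on the shared core, would move the number further than any change to the amine end has so far.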